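Removing the Chlorophenyl Group: Expected Loss of Toxicity

This account rests on a few compounds, and the source may have more. Where it says the series, first, only, none or still open, it means among the compounds named here.

All three measured compounds were tested in an ADME assay on MT4 cells (Homo sapiens) for cytotoxicity, read by MTT assay, with a stated time of 4 days; a higher number here means that more compound is tolerated, a lower number that less compound is tolerated:
Compound 1, `O=C1c2sccc2NS(=O)(=O)N1Cc1ccccc1`, gives 374000 nM.
Compound 2, `N#Cc1ccccc1CN1c2ccsc2C(=O)N(Cc2ccccc2)S1(=O)=O`, gives only a limit of the assay, > 305000 nM.
Compound 3, `O=C1c2sccc2N(Cc2ccc(Cl)cc2)S(=O)(=O)N1Cc1ccccc1`, gives 8200 nM.

Compound 3 holds the lowest of the two readable numbers, and the nearest number is that of compound 1, reached by a 46-fold lower number from compound 1 to compound 3 (1.66 log units; beyond the scatter). The value of compound 2 is a limit and not a number (the limit of > 305000 nM in this assay, at which 1 of the 3 values shown sits).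

Compound 4, `N#CCN1c2ccsc2C(=O)N(Cc2ccccc2)S1(=O)=O`, is not yet measured. It differs from compound 3 in one place: cyano in place of 4-chlorophenyl on a saturated chain carbon bound to a sulfonamide nitrogen in a ring. For the measured compounds named here, two measured steps bear on this change. Adding 4-chlorobenzyl to the sulfonamide nitrogen gave a 46-fold lower number from compound 1 to compound 3 (1.66 log units; beyond the scatter), and exchanging 2-cyanophenyl for 4-chlorophenyl on that chain carbon gave an at least 37-fold lower number from compound 2 to compound 3 (1.57 log units; beyond the scatter). Both point the same way: the 4-chlorophenyl group goes with a much lower number, while compound 1 and compound 2, which lack it, sit far higher. Compound 4 lacks that group too, and its number in this assay is therefore expected to rise far above that of compound 3, 8200 nM, toward the region of compound 1.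

For compound 4 the expected value is 200000 nM, with a range from 40000 nM to 400000 nM. That corresponds to an expected step of a 24-fold higher number from compound 3 to compound 4 (1.39 log units; beyond the scatter).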

Compound 4, half-maximal cytotoxic concentration: 5700 nM
Estimate against measurement, compound 4: 35-fold (1.55 log units) above; measured number outside the range, below it.
By their numbers in this assay, from the lowest: compounds 4 and 3 (each within the scatter of the next); then compound 1.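

In this assay, the low number does not depend on the 4-chlorophenyl group at this place, on a saturated chain carbon bound to a sulfonamide nitrogen in a ring: cyano in its place gives a 1.4-fold lower number from compound 3 to compound 4 (0.16 log units; within the scatter), and cyanomethyl in place of hydrogen on the sulfonamide nitrogen gives a 66-fold lower number from compound 1 to compound 4 (1.82 log units; beyond the scatter), so the much smaller cyanomethyl goes with a fall of similar size to that seen with 4-chlorobenzyl. Among the groups shown on that nitrogen, compound 2 is the exception, since its 2-cyanobenzyl group does not go with a low number, and cyano in place of 2-cyanophenyl gives an at least 53-fold lower number from compound 2 to compound 4 (1.72 log units; beyond the scatter). The value of compound 2 is a limit of the assay and not a number: the limit of > 305000 nM in this assay, at which 1 of the 4 values shown sits.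

The compounds shown leave open whether the low number also holds for an amine or a carboxylic acid on that chain carbon, or only for cyano and 4-chlorophenyl. They also leave open what sets 2-cyanophenyl apart from 4-chlorophenyl, and a plain phenyl group at this place would begin to separate the role of the nitrile from that of the chlorine.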